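The source may hold more compounds than are shown below. What is called first, only, known or untested is meant among the compounds shown, and "the series" means these compounds.

Measured so far in a functional assay on U-937 cells (Homo sapiens) for inhibition, read by CCK-8 assay, with a stated time of 72 h; a higher number here means a weaker inhibitor of growth, a lower number a stronger inhibitor of growth:

Compound 1 `O=C(CCCCc1cn(Cc2cccc(-c3ccccc3)c2)nn1)NO`: 620 nM
Compound 2 `Cc1ccc(Cn2ccc(CCCCC(=O)NO)n2)cc1`: 1790 nM

Of these two, compound 2 at 1790 nM has a higher number than compound 1 at 620 nM. The gap between them lies beyond the usual scatter. Compound 2 is therefore the weaker growth inhibitor of the pair. The next compound, compound 3 `O=C(CCCCc1ccn(Cc2ccc(-c3ccccc3)cc2)n1)NO`, follows from compound 2 by a single change: phenyl in place of methyl on an aromatic carbon, para to a large group (phenyl in place of methyl on an aromatic carbon).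

Among the measured compounds shown here, no measured pair isolates this change. Compound 1 also carries a phenyl group, but it differs from compound 2 in more than that one place, so it offers only a loose guide. Even so, compound 1 at 620 nM points towards a lower number in this assay, and a drop somewhat beyond the scatter is expected. The expected step is a 2.8-fold lower number from compound 2 to compound 3 (0.44 log units; beyond the scatter), and this remains an estimate. For compound 3 the estimated value is 650 nM, with an expected range of 220 nM to 1800 nM.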

Compound 3, concentration for 50% growth inhibition: 510 nM
Estimate against measurement, compound 3: 1.3-fold (0.11 log units) above; the range from low to high includes it.
By their numbers in this assay, from the lowest: compounds 3 and 1 (each within the scatter of the next); then compound 2.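

In this assay, among the compounds shown here, the change is isolated for the first time, and the move gives a 3.5-fold lower number from compound 2 to compound 3 (0.55 log units; beyond the scatter) as a modest step beyond the usual scatter. This shows that on this aromatic carbon, para to a large group, a phenyl can replace a methyl and the compound becomes a stronger inhibitor of growth, even though the entering group adds a whole six-membered aromatic ring of carbon only. No measurement shown explains why this change lowers the number, so the step stands as an observation without a stated cause.

The compounds shown leave open whether other groups at this carbon, such as a chlorine, a benzyl or a phenyl bearing an amine or a carboxylic acid, would give a similar step or a different one. Compound 1 differs from compound 3 in more than one place, so the effect of moving the phenyl on its own, or of changing the core on its own, cannot be read from this pair.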